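Adding One Methyl to Compound 2

The source may report more compounds than this note shows. Statements on the series, on what has been measured and on what is new or still open speak of the compounds shown alone.

In an ADME assay on MRC5 cells (Homo sapiens) for cytotoxicity, read by resazurin assay, with a stated time of 72 h (on this read-out higher numbers stand for weaker inhibition and lower numbers for stronger inhibition), compound 2 `O=[N+]([O-])c1cn2c(n1)OC(CN1CCC(c3ccc(F)cc3)CC1)CC2` gives > 64000 nM, which is a limit of the assay and not a number. Compound 1 `CC1(CN2CCC(Oc3ccc(F)cc3)CC2)CCn2cc([N+](=O)[O-])nc2O1` gives > 64000 nM, also a limit. Compound 3 `CC1(CN2CCC(c3ccc(F)cc3)CC2)CCn2cc([N+](=O)[O-])nc2O1` is compound 2 with methyl in place of hydrogen on a saturated ring carbon, next to the ring oxygen: methyl in place of hydrogen on a saturated ring carbon. Among the measured compounds shown here, no measured pair shows this change, so the expectation rests on compound 2 and compound 1, with the limit of > 64000 nM in this assay, at which 2 of the 2 values shown sit. No change beyond the usual scatter is expected in either direction, and the expected step is an at least 1.0-fold lower number from compound 2 to compound 3 (0.02 log units; that floor lies within the scatter). Compound 3 is estimated at 60000 nM, with an expected range of 30000 nM to 64000 nM.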

Compound 3, half-maximal inhibitory concentration: > 64000 nM
Compound 3: no number, only a limit; the forecaster's own chance of this, stated with the estimate: 85%; at least 1.0-fold (0.02 log units) between middle value and limit.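

In this assay, among the compounds shown here, no step from compound 2 or compound 1 to compound 3 can be read, since all three compounds give only a limit: the limit of > 64000 nM in this assay, at which 3 of the 3 values shown sit.

The compounds shown leave open whether methyl in place of hydrogen changes this read-out at all.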